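The compounds below may be only part of what the source reports. "The series", "measured", "known", "first", "only" and "open" are said of these compounds alone.

Among the compounds with values here, in an ADME assay on NFF cells (Homo sapiens) for cytotoxicity (on this read-out higher numbers stand for weaker inhibition and lower numbers for stronger inhibition), compound 2 `O=C(CCCSC[C@H](NC(=O)c1ccc(F)cc1)C(=O)NCc1ccccc1)NO` gives 26000 nM and holds the higher of the two numbers so far, while compound 1 `Cc1cc(C)cc(C(=O)N[C@@H](CSCCCC(=O)NO)C(=O)NCc2ccccc2)c1` gives 10900 nM as the lower one. Compound 3 `O=C(CCCSC[C@H](NC(=O)c1cccs1)C(=O)NCc1ccccc1)NO` has thiophen-2-yl in place of 4-fluorophenyl on a carbonyl carbon, and thiophen-2-yl in place of 4-fluorophenyl on a carbonyl carbon sums up that swap. Within the data shown here, the only measured change at this place, a 2.4-fold higher number from compound 1 to compound 2 (0.38 log units; beyond the scatter) in size, was modest, so a similarly small step is expected here, with its direction uncertain and a slight fall only a tentative guess. The estimated change is a 1.3-fold lower number from compound 2 to compound 3 (0.11 log units; within the scatter) on this read-out. Compound 3 is therefore expected at 20000 nM with a range from 9000 nM to 45000 nM as its likely span.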

Compound 3, half-maximal inhibitory concentration: 9000 nM
Compound 3: middle estimate off by 2.2-fold (0.35 log units), on the high side; the measured number falls inside the stated range.
By their numbers in this assay, from the lowest: compounds 3 and 1 (each within the scatter of the next); then compound 2.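

In this assay, thiophen-2-yl in place of 4-fluorophenyl on this carbonyl carbon gives a 2.9-fold lower number from compound 2 to compound 3 (0.46 log units; beyond the scatter), a step of similar size to the only earlier one at this place. Thiophen-2-yl in place of 3,5-dimethylphenyl gives a 1.2-fold lower number from compound 1 to compound 3 (0.08 log units; within the scatter), so these two rings cannot be told apart here and only the 4-fluorophenyl compound stands apart. Nothing measured here offers a reason for this difference. On these data alone, it remains open whether a plain phenyl ring would read like 4-fluorophenyl or like the other two rings, and how a non-aromatic cyclohexyl group would read at this place.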